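The compounds below may be only part of what the source reports. "The series", "measured", "known", "first", "only" and "open" are said of these compounds alone.

Measured so far:
Compound 1, `CCN1CCC(n2cc(S(=O)(=O)c3cccc(F)c3)c3cccnc32)C1`: 8.3 nM
Compound 2, `CCN1CCC(n2cc(S(=O)(=O)c3cccc(Cl)c3)c3cccnc32)C1`: 3.3 nM
Compound 3, `CCN1CCC(n2cc(S(=O)(=O)C3=C(Cl)NC4SC=CN34)c3cccnc32)C1`: 1.4 nM

All three were tested in an assay on HeLa cells for displacement of a labelled ligand from 5-hydroxytryptamine receptor 6 (Homo sapiens); a lower number here means a stronger inhibitor, a higher number a weaker inhibitor. Among these three numbers compound 1 stands highest. Its nearest neighbour is compound 2, reached by a 2.5-fold lower number from compound 1 to compound 2 (0.40 log units; beyond the scatter), and the furthest is compound 3, reached by a 5.9-fold lower number from compound 1 to compound 3 (0.77 log units; beyond the scatter). The remaining comparison, a 2.4-fold lower number from compound 2 to compound 3 (0.37 log units; beyond the scatter), points the same way. Every one of these steps alters the group attached to the sulfonyl sulfur, and nothing else.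

Compound 4, `CN1CCCC(n2cc(S(=O)(=O)c3cccc(F)c3)c3cccnc32)C1`, keeps that sulfonyl side exactly as in compound 1 and changes a different part of the molecule: 1-methylpiperidin-3-yl in place of 1-ethylpyrrolidin-3-yl on an aromatic nitrogen. The two compounds contain the same atoms, joined differently. Among the compounds with values here, no measured step touches this ring on the aromatic nitrogen, so there is no comparison that bears on the change directly. Without such a comparison the cautious expectation is a number close to that of compound 1, with no step beyond the scatter in either direction.

The estimate for compound 4 in this assay is therefore 8 nM, with a range from 3 nM to 25 nM. For compound 4 this means an expected step of a 1.0-fold lower number from compound 1 to compound 4 (0.02 log units; within the scatter).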

Compound 4, inhibition constant: 4.7 nM
Compound 4: the middle estimate sits 1.7-fold (0.23 log units) above what was measured; measured number inside the range.
By their numbers in this assay, from the lowest: compound 3; then compounds 2, 4 and 1 (each within the scatter of the next, the first and the last beyond it).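

In this assay, 1-methylpiperidin-3-yl in place of 1-ethylpyrrolidin-3-yl on the aromatic nitrogen gives a 1.8-fold lower number from compound 1 to compound 4 (0.25 log units; within the scatter), the only view so far of this part of the molecule, as every earlier step altered the sulfonyl side. With the sulfonyl side of compound 1 held fixed, this assay does not separate the two groups, so this position accepts a six-membered ring carrying a methyl group as well as a five-membered ring carrying an ethyl group. Nothing measured here explains why the two groups read alike.

Ring size and the chain on the ring nitrogen change together in this single step, so a 1-ethylpiperidin-3-yl or 1-methylpyrrolidin-3-yl group would be needed to look at each change on its own, while a longer chain such as propyl on that nitrogen, or a plain hydrogen there, remains an open question. Going by these compounds, it also remains open whether 1-methylpiperidin-3-yl behaves the same way when paired with the sulfonyl side of compound 2 or compound 3, which both give lower numbers than compound 1.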